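The source may hold more compounds than are shown below. What is called first, only, known or untested is meant among the compounds shown, and "the series" means these compounds.

Measured compounds:
- compound 1 `CN(C)CCn1cnnc1-c1cc(Oc2ccc(NC(=O)Nc3cccc(C(F)(F)F)c3)cc2F)ccn1`, in a functional assay on NCI-H460 cells (Homo sapiens) for antiproliferative activity, read by MTT assay, with a stated time of 72 h (a higher number here means a weaker inhibitor, a lower number a stronger inhibitor), compound 1 gives 2150 nM
- compound 2 `CN(C)CCn1cnnc1-c1cc(Oc2ccc(NC(=O)Nc3ccccc3C(F)(F)F)cc2F)ccn1`, in this assay compound 2 reaches only the limit > 50000 nM, so no number is known for it
- compound 3 `CN(C)CCn1cnnc1-c1cc(Oc2ccc(NC(=O)Nc3ccc(F)c(F)c3)cc2F)ccn1`, in this assay compound 3 gives 9050 nM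

Compound 3 holds the higher of the two numbers shown; compound 1 sits lower by a 4.2-fold higher number from compound 1 to compound 3 (0.62 log units; beyond the scatter), while compound 2 stands at a limit (the limit of > 50000 nM in this assay, at which 1 of the 3 values shown sits). Compound 4 `CN(C)CCn1cnnc1-c1cc(Oc2ccc(NC(=O)Nc3ccc(Cl)cc3Cl)cc2F)ccn1` differs from compound 3 in one place: 2,4-dichlorophenyl in place of 3,4-difluorophenyl on an amide-type nitrogen. Of the measured steps, an at least 23-fold higher number from compound 1 to compound 2 (1.36 log units; beyond the scatter) is the closest guide, as the group names 2-(trifluoromethyl)phenyl and 2,4-dichlorophenyl both begin with a 2; that step was a large loss. The step of an at least 5.5-fold lower number from compound 2 to compound 3 (0.74 log units; beyond the scatter) shows the same group in reverse, and a 4.2-fold higher number from compound 1 to compound 3 (0.62 log units; beyond the scatter) shows that changing the halogen pattern alone costs a modest amount. Compound 4 is therefore expected to be a weaker inhibitor than compound 3, with a likely step of a 2.4-fold higher number from compound 3 to compound 4 (0.39 log units; beyond the scatter), and a limit rather than a number is a real possibility. The estimate for compound 4 is 22000 nM, with a range from 7000 nM to 60000 nM.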

Compound 4, half-maximal inhibitory concentration: 4350 nM
For compound 4 the middle estimate is 5.1-fold (0.70 log units) above the measured one; the whole stated range lies above it.
By their numbers in this assay, from the lowest: compound 1; then compound 4; then compound 3. At a limit, above all of these: compound 2.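

A group whose name begins with a 2 does not by itself end activity on this amide-type nitrogen: in this assay, the change from 3,4-difluorophenyl to 2,4-dichlorophenyl brings a 2.1-fold lower number from compound 3 to compound 4 (0.32 log units; beyond the scatter). The same group brings an at least 11-fold lower number from compound 2 to compound 4 (1.06 log units; beyond the scatter) when it replaces 2-(trifluoromethyl)phenyl, but a 2.0-fold higher number from compound 1 to compound 4 (0.31 log units; beyond the scatter) when it replaces 3-(trifluoromethyl)phenyl, so 3-(trifluoromethyl)phenyl remains the best of these four groups in this assay. The entry for compound 2 is a limit and not a number: the limit of > 50000 nM in this assay, at which 1 of the 4 values shown sits.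

On these data alone, it remains open how 2-chlorophenyl and 4-chlorophenyl, each with a single chlorine, would compare with 2,4-dichlorophenyl. Also open, as far as these compounds go, is how an unsubstituted phenyl ring, or a phenyl ring carrying a methoxy group or an amine, would fare at this position.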